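This account rests on a few compounds, and the source may have more. Where it says the series, first, only, none or still open, it means among the compounds named here.

Measured so far in an assay on HEK293 cells for displacement of a labelled ligand from Neuronal acetylcholine receptor; alpha4/beta2 (Homo sapiens), read by scintillation counting, with a stated time of 120 min; a lower number here means a stronger inhibitor, a higher number a weaker inhibitor: compound 1 `Fc1ccc(COc2cccc(-c3cn(C4CN5CCC4CC5)nn3)c2)cc1` gives 1010 nM; compound 2 `c1ccc(COc2cccc(-c3cn(C4CN5CCC4CC5)nn3)c2)cc1` gives 668 nM; compound 3 `FCCOc1cccc(-c2cn(C3CN4CCC3CC4)nn2)c1` gives 1960 nM.

Among the measured compounds shown here, compound 3 shows the highest of the three numbers, though its gap to compound 1 is within the scatter, and only the step of a 2.9-fold higher number from compound 2 to compound 3 (0.47 log units; beyond the scatter) lies beyond it. Compound 4 `FCCCOc1cccc(-c2cn(C3CN4CCC3CC4)nn2)c1` carries the change (fluoromethyl in place of fluoro on a saturated chain carbon, two bonds along the chain from an oxygen on an aromatic ring). For the measured compounds named here, no measured step lengthens this chain by one carbon, so the nearest guides are a 1.9-fold higher number from compound 1 to compound 3 (0.29 log units; within the scatter) and a 2.9-fold higher number from compound 2 to compound 3 (0.47 log units; beyond the scatter), where the larger groups bound to the oxygen went with the lower numbers. A small downward step in this assay, or none beyond the scatter, is therefore expected. Compound 4 is estimated at 1400 nM, within 500 nM to 4000 nM, an expected step of a 1.4-fold lower number from compound 3 to compound 4 (0.15 log units; within the scatter).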

Compound 4, inhibition constant: 3890 nM
Beside the measured number, compound 4's estimate is 2.8-fold (0.44 log units) below it; the measured number falls inside the stated range.
By their numbers in this assay, from the lowest: compounds 2, 1, 3 and 4 (each within the scatter of the next, the first and the last beyond it).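

In this assay, going from 2-fluoroethoxy to 3-fluoropropoxy gives no separation that can be trusted (a 2.0-fold higher number from compound 3 to compound 4 (0.30 log units; within the scatter)). The fluorinated chain now stands clearly apart from the 4-fluorophenyl group as well as the phenyl group, not only the latter (a 3.9-fold higher number from compound 1 to compound 4 (0.59 log units; beyond the scatter); a 5.8-fold higher number from compound 2 to compound 4 (0.77 log units; beyond the scatter)). No measurement shown explains these gaps. Still open, as far as these compounds go, is how a longer chain such as 4-fluorobutyl would read, and whether a hydroxyl or an amine in place of the chain-end fluoro would shift the number.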